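From 4-chlorophenyl to 3-ethylphenyl on the amide

The compounds below may be only part of what the source reports. "The series", "measured", "known", "first", "only" and "open" are said of these compounds alone.

Measured so far in a physicochemical assay, with a stated time of 30 min; on this read-out lower numbers stand for stronger inhibition and higher numbers for weaker inhibition
Compound 1 `COc1ccc(NC(=O)C2Cc3cc(OC)c(OC)cc3C2=O)cc1` gives 49.5 ug/mL
Compound 2 `COc1cc2c(cc1OC)C(=O)C(C(=O)Nc1ccc(Cl)cc1)C2` gives 56.8 ug/mL

Compound 2, at 56.8 ug/mL, lies within the scatter of compound 1. Compound 3 `CCc1cccc(NC(=O)C2Cc3cc(OC)c(OC)cc3C2=O)c1` differs from compound 2 by 3-ethylphenyl in place of 4-chlorophenyl on an amide-type nitrogen. Going by the values given here, the only measured step is a 1.1-fold higher number from compound 1 to compound 2 (0.06 log units; within the scatter), with chloro in place of methoxy on an aromatic carbon. Among the compounds with values here, no compound with an ethyl group has been measured, so this is thin guidance. The expected change in this assay is a 1.0-fold lower number from compound 2 to compound 3 (0.01 log units; within the scatter), nothing beyond the scatter in either direction. Compound 3 is estimated at 55 ug/mL, with an expected range of 25 ug/mL to 115 ug/mL.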

Compound 3, half-maximal inhibitory concentration: 64.1 ug/mL
The estimate for compound 3 lay 1.2-fold (0.07 log units) below the measured number; the measured number falls inside the stated range.
By their numbers in this assay, from the lowest: compounds 1, 2 and 3 (each within the scatter of the next).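

In this assay, replacing the aryl group on the amide-type nitrogen with 3-ethylphenyl gives a 1.1-fold higher number from compound 2 to compound 3 (0.05 log units; within the scatter) and a 1.3-fold higher number from compound 1 to compound 3 (0.11 log units; within the scatter). The earlier step changed only the group at one ring position, whereas these steps change both the group and its place on the ring, and all three compounds still lie within the scatter. No available measurement offers an explanation for this result.

As far as these compounds go, whether an amine, a carboxylic acid or a longer chain on this ring would give a step beyond the scatter remains open. Changes to the shared core also remain untested here.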